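Thiosemicarbazones on a shared terpenoid core: aryl variation

The compounds below may be only part of what the source reports. "The series", "measured", "known", "first", "only" and "open" are said of these compounds alone.

Measured so far:
compound 1 `CC1=CC[C@H](C(C)(C)NC(=S)N/N=C/c2ccccc2)CC1` 53900 nM
compound 2 `CC1=CC[C@H](C(C)(C)NC(=S)N/N=C/c2ccccc2O)CC1` 8400 nM
compound 3 `CC1=CC[C@H](C(C)(C)NC(=S)N/N=C/c2ccc(F)cc2)CC1` limit > 100000 nM

In a functional assay on NCI-H460 cells (Homo sapiens) for inhibition, read by sulforhodamine B assay, with a stated time of 48 h (a higher number here means a weaker inhibitor of growth, a lower number a stronger inhibitor of growth), compound 1 gives 53900 nM and stands as the highest of the two numbers recorded; the nearest is compound 2, which gives 8400 nM. Compound 3 reaches only the limit of the limit of > 100000 nM in this assay, at which 1 of the 3 values shown sits, and yields no number. The two measured steps from compound 1 are the hydroxy step, a 6.4-fold lower number from compound 1 to compound 2 (0.81 log units; beyond the scatter), and the fluoro step, an at least 1.8-fold higher number from compound 1 to compound 3 (0.26 log units; that floor lies within the scatter); between the two substituted compounds the step is an at least 11-fold higher number from compound 2 to compound 3 (1.07 log units; beyond the scatter).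

Compound 4 `CC1=CC[C@H](C(C)(C)NC(=S)N/N=C/c2ccc[nH]2)CC1` differs from compound 1 by 1H-pyrrol-2-yl in place of phenyl on a carbon with a double bond to nitrogen. Neither measured step replaces the whole ring; both change only one substituent on the phenyl, so they bear only loosely on this change. Among the measured compounds shown here, the hydroxy step shows that a hydrogen-bond donor on the aryl part can go with a lower number, but the pyrrole change is a different one and no step of that kind is available. The expectation is therefore a step of a 1.2-fold lower number from compound 1 to compound 4 (0.08 log units; within the scatter), within the scatter, with wide uncertainty. Compound 4 is expected at 45000 nM, between 12000 nM and 100000 nM.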

Compound 4, concentration for total growth inhibition: 57500 nM
Beside the measured number, compound 4's estimate is 1.3-fold (0.11 log units) below it, and the stated range covers the measured number.
By their numbers in this assay, from the lowest: compound 2; then compounds 1 and 4 (each within the scatter of the next). At a limit, above all of these: compound 3.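

In this assay, replacing the whole phenyl ring with 1H-pyrrol-2-yl on the carbon with a double bond to nitrogen gives a 1.1-fold higher number from compound 1 to compound 4 (0.03 log units; within the scatter), so this step, to a five-membered aromatic ring with 1 hetero atom, stays within the scatter. A hydrogen-bond donor on the aromatic ring is not enough to match 2-hydroxyphenyl, since the step to the pyrrole is a 6.8-fold higher number from compound 2 to compound 4 (0.84 log units; beyond the scatter). Compound 3 stands at a limit and not at a number: the limit of > 100000 nM in this assay, at which 1 of the 4 values shown sits.
Read from that limit, the step is an at least 1.7-fold lower number from compound 3 to compound 4 (0.24 log units; that floor lies within the scatter), and it gives only a floor.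

Open, going by these compounds, is whether a methoxy group or an amine in place of the hydroxy of compound 2 keeps its lower number. Also open, on these data alone, is whether a furan or pyridine ring in place of 1H-pyrrol-2-yl reads as compound 4 does.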